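Swapping the aryl group on a shared pyrimidine-piperidine sulfamide core

The source may hold more compounds than are shown below. What is called first, only, known or untested is meant among the compounds shown, and "the series" means these compounds.

Measured compounds:
- compound 1 `Cc1ccc(-c2cc(N3CCC(CNS(N)(=O)=O)CC3)ncn2)cc1`: 71000 nM
- compound 2 `COc1ccc(-c2cc(N3CCC(CNS(N)(=O)=O)CC3)ncn2)cc1`: > 100000 nM
- compound 3 `CCOC(=O)c1ccc(-c2cc(N3CCC(CNS(N)(=O)=O)CC3)ncn2)cc1`: 5000 nM

In a functional assay on M21 cells (Homo sapiens) for antiproliferative activity, read by sulforhodamine B assay, with a stated time of 48 h (on this read-out higher numbers stand for weaker inhibition of growth and lower numbers for stronger inhibition of growth), compound 2 gives only a limit, > 100000 nM, with no number behind it. Compound 1 gives 71000 nM, and the step of an at least 1.4-fold higher number from compound 1 to compound 2 (0.14 log units; that floor lies within the scatter) is within the scatter. Compound 3 gives 5000 nM, so a 14-fold lower number from compound 1 to compound 3 (1.15 log units; beyond the scatter) and an at least 20-fold lower number from compound 2 to compound 3 (1.30 log units; beyond the scatter) are large improvements. Compound 4 `NS(=O)(=O)NCC1CCN(c2cc(-c3ccccc3Cl)ncn2)CC1` differs from compound 2 by 2-chlorophenyl in place of 4-methoxyphenyl on an aromatic carbon. For the measured compounds named here, none of the measured steps exchanges the whole aryl group or places a substituent on an aromatic carbon of this kind, so no measured step bears directly on it; the measured steps only show that the aryl substituent can move this assay by large amounts. Compound 4 is therefore expected at 50000 nM, between 10000 nM and 150000 nM, meaning an expected step of an at least 2.0-fold lower number from compound 2 to compound 4 (0.30 log units; that floor lies within the scatter).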

Compound 4, concentration for 50% growth inhibition: > 100000 nM
Compound 4: a limit, no number (the forecaster's own chance of this, stated with the estimate: 40%); middle value at least 2.0-fold (0.30 log units) away from the limit.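

In this assay compound 4 gives only a limit, not a number. The result is an at least 1.4-fold higher number from compound 1 to compound 4 (0.14 log units; that floor lies within the scatter), so 2-chlorophenyl shows no gain over 4-methylphenyl, and the steps that compare compound 4 with compound 2 cannot be read. Compound 4 therefore shows none of the gain seen with the ethoxycarbonyl group of compound 3, and it shares its limit with compound 2: the limit of > 100000 nM in this assay, at which 2 of the 4 values shown sit.

The compounds shown leave open whether the gain depends on the ethoxycarbonyl group itself. A carboxylic acid or an amide in its place could test this.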